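The source may report more compounds than this note shows. Statements on the series, on what has been measured and on what is new or still open speak of the compounds shown alone.

Measured so far in a functional assay on Malme-3M cells (Homo sapiens) for inhibition, read by sulforhodamine B assay, with a stated time of 48 h, tested at 100 uM; on this read-out lower numbers stand for a stronger effect and higher numbers for a weaker effect at the one concentration tested:
compound 1 `COc1cc(Cl)cc(-c2nn(-c3cccc(NC(=O)Nc4ccc(Cl)c(C(F)(F)F)c4)c3)cc2-c2ccncc2)c1` gives -35%
compound 2 `COc1cc(Cl)cc(-c2nn(-c3cccc(NC(=O)Nc4ccc(Cl)c(Cl)c4)c3)cc2-c2ccncc2)c1` gives -24%
compound 3 `COc1cc(Cl)cc(-c2nn(-c3cccc(NC(=O)Nc4cccc(C(F)(F)F)c4)c3)cc2-c2ccncc2)c1` gives -26%

Compound 3 stands second highest of the three numbers. Its nearest neighbour is compound 2, with a number 2 percentage points lower from compound 2 to compound 3 (within the scatter), and the furthest is compound 1, with a number 9 percentage points higher from compound 1 to compound 3 (within the scatter); both gaps lie within the scatter, so the three compounds cannot be ranked against one another.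

Compound 4 `COc1cc(Cl)cc(-c2nn(-c3cccc(NC(=O)c4cccc(C(F)(F)F)c4)c3)cc2-c2ccncc2)c1` differs from compound 3 in one place: 3-(trifluoromethyl)phenyl in place of (3-(trifluoromethyl)phenyl)amino on a carbonyl carbon. Going by the values given here, the measured steps, a number 11 percentage points higher from compound 1 to compound 2 (beyond the scatter) and the two just named, all concern the ring at the far end of the shared core, while the carbonyl carbon and its neighbours stayed the same; no measured step therefore bears on this change. Among the compounds with values here, the only guide is that the three values sit close together at this concentration. On that basis a step of a number 11 percentage points higher from compound 3 to compound 4 (beyond the scatter) is expected, with no direction firmly expected. Compound 4 is estimated at -15%, with a range from -40% to 10%.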

Compound 4, a percentage reported as activity, at one concentration (the size of the read-out at that concentration, not a potency): 55%
Beside the measured number, compound 4's estimate is 70 percentage points below it; measured number outside the range, above it.
By their numbers in this assay, from the lowest: compounds 1, 3 and 2 (each within the scatter of the next, the first and the last beyond it); then compound 4.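

In this assay, going by these compounds alone, putting 3-(trifluoromethyl)phenyl directly on the carbonyl carbon in place of (3-(trifluoromethyl)phenyl)amino gives a number 81 percentage points higher from compound 3 to compound 4 (beyond the scatter) and is the largest kind of change seen so far, whereas the earlier steps among compounds 1, 2 and 3 were modest or within the scatter. The steps of a number 79 percentage points higher from compound 2 to compound 4 (beyond the scatter) and a number 90 percentage points higher from compound 1 to compound 4 (beyond the scatter) go the same way and are of similar size, although each also alters the substituents on the ring, so the amino nitrogen on the carbonyl carbon is where this series turns out to be sensitive, and compound 4 has the weakest effect of the four. The group that leaves carries a hydrogen-bond donor and the group that enters carries none, but nothing measured here says why the number rises so far or whether that donor plays any part.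

The compounds shown leave open whether the nitrogen itself counts, or only the presence of a linking atom, which a methylene group, an oxygen atom or a methylamino group on the carbonyl carbon would help to separate. They also leave open whether the same step holds with 3,4-dichlorophenyl or 4-chloro-3-(trifluoromethyl)phenyl placed directly on the carbonyl carbon.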